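The source may hold more compounds than are shown below. What is called first, only, known or untested is meant among the compounds shown, and "the series" means these compounds.

Measured so far in a functional assay on MDA-MB-231 cells (Homo sapiens) for antiproliferative activity, read by MTT assay, with a stated time of 72 h; a higher number here means a weaker inhibitor, a lower number a stronger inhibitor:

Compound 1 `COc1cc(OC)cc(-c2cccc(NC(=O)CCc3cccc4c3COB4O)c2)c1`: 93000 nM
Compound 2 `CC(=O)c1ccc(-c2cccc(NC(=O)CCc3cccc4c3COB4O)c2)cc1`: 41000 nM
Compound 3 `COc1cc(OC)cc(-c2cccc(NC(=O)CCc3ccccc3)c2)c1`: 87000 nM

All three compounds carry the same amide-linked chain on a biphenyl-type scaffold and differ in one place each. Compound 2 differs from compound 1 by 4-acetylphenyl in place of 3,5-dimethoxyphenyl on an aromatic carbon; in this assay that gave a 2.3-fold lower number from compound 1 to compound 2 (0.36 log units; beyond the scatter), so compound 2 stands with the lowest number of the three. Compound 3 differs from compound 1 by a group of 6 heavy atoms (6 carbon; one six-membered aromatic ring of carbon only) in place of a group of 10 heavy atoms (7 carbon, 1 boron, 2 oxygen; one five-membered non-aromatic ring with 2 hetero atoms, one six-membered aromatic ring of carbon only), on a saturated chain carbon, two bonds along the chain from a carbonyl carbon. That replacement gave a 1.1-fold lower number from compound 1 to compound 3 (0.03 log units; within the scatter), which means the two numbers cannot be told apart.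

Compound 4 `CC(=O)c1ccc(-c2cccc(NC(=O)CCc3ccccc3)c2)cc1` has not yet been measured in this assay. It differs from compound 2 by a group of 6 heavy atoms (6 carbon; one six-membered aromatic ring of carbon only) in place of a group of 10 heavy atoms (7 carbon, 1 boron, 2 oxygen; one five-membered non-aromatic ring with 2 hetero atoms, one six-membered aromatic ring of carbon only), on a saturated chain carbon, two bonds along the chain from a carbonyl carbon. For the measured compounds named here, this is the same change as the one from compound 1 to compound 3: the group that leaves, the group that enters and the place are described in the same words for both pairs. The only thing that sets the two pairs apart is the core, and the two cores differ exactly as already set out for compound 1 and compound 2.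

Because a 1.1-fold lower number from compound 1 to compound 3 (0.03 log units; within the scatter) fell within the usual scatter, the step expected from compound 2 to compound 4 is similarly small, a 1.1-fold higher number from compound 2 to compound 4 (0.04 log units; within the scatter). On that basis compound 4 is estimated at 45000 nM in this assay, with a likely span from 20000 nM to 100000 nM.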

Compound 4, half-maximal inhibitory concentration: 2700 nM
The estimate for compound 4 lay 17-fold (1.22 log units) above the measured number, and the stated range ends above it.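

In this assay, putting phenyl in place of the boron-bearing group of 10 heavy atoms gave a 15-fold lower number from compound 2 to compound 4 (1.18 log units; beyond the scatter), whereas the same change on the core of compound 1 left no difference that could be told from scatter. For the compounds shown here, the effect of this change therefore does not carry over unchanged from one core to the other: the same change on two cores in this assay, a 1.1-fold lower number (0.03 log units; within the scatter) from compound 1 to compound 3 and a 15-fold lower number (1.18 log units; beyond the scatter) from compound 2 to compound 4, 14-fold (1.15 log units) apart, beyond the scatter of two such steps What this does not show is why the two cores part ways, and with only two pairs to compare, it cannot say which of the two outcomes a further core would follow.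

The compounds shown leave open whether the large step depends on the acetyl group itself, or whether a 4-cyanophenyl or 4-carboxyphenyl group in place of 4-acetylphenyl would show the same large step when the boron-bearing group is replaced by phenyl. They also leave open whether a longer chain between the carbonyl and the phenyl, or an amine on that phenyl, would keep the number near that of compound 4, which gives 2700 nM.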